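The source may report more compounds than this note shows. Statements on the series, on what has been measured and on what is new or still open speak of the compounds shown alone.

Compound 1 `C=C(Br)C(=O)Nc1ccc(/C=C2\SC(=O)N(Cc3ccc(Cl)cc3)C2=O)cc1` gives 5100 nM in a functional assay on FM3A cells (Mus musculus) for cytotoxicity, read by cell counting, with a stated time of 2 days (a higher number here means a weaker inhibitor, a lower number a stronger inhibitor), the lowest of the two numbers recorded there. Compound 3 `Nc1ccc(/C=C2\SC(=O)N(Cc3ccc(Cl)cc3)C2=O)cc1` gives 60000 nM in this assay. Compound 2 `Nc1cccc(/C=C2\SC(=O)N(Cc3ccccc3)C2=O)c1` reaches only a limit of this assay, > 250000 nM. Among the measured compounds shown here, the one measured step, a 12-fold higher number from compound 1 to compound 3 (1.07 log units; beyond the scatter), concerns the nitrogen on the aromatic ring, not the benzyl ring. For the measured compounds named here, compound 4 `C=C(Br)C(=O)Nc1ccc(/C=C2\SC(=O)N(Cc3ccc(F)cc3)C2=O)cc1` differs from compound 1 by fluoro in place of chloro on an aromatic carbon, a place that no measured step touches. Because a 12-fold higher number from compound 1 to compound 3 (1.07 log units; beyond the scatter) bears on a different position, no guidance exists for the halogen swap; the expected step is none beyond the scatter, so compound 4 is estimated at 5100 nM, between 2500 nM and 10000 nM, meaning no change at the digits printed from compound 1 to compound 4 (within the scatter).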

Compound 4, half-maximal inhibitory concentration: 4600 nM
Compound 4: the middle estimate sits 1.1-fold (0.04 log units) above what was measured; low and high end bracket the measured number.
By their numbers in this assay, from the lowest: compounds 4 and 1 (each within the scatter of the next); then compound 3. At a limit, above all of these: compound 2.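

In this assay, among the compounds shown here, the first measured step on the benzyl ring is a 1.1-fold lower number from compound 1 to compound 4 (0.04 log units; within the scatter), so at this aromatic carbon para to a large group, chloro and fluoro are not told apart. This contrasts with the larger step at the nitrogen on the aromatic ring, a 12-fold higher number from compound 1 to compound 3 (1.07 log units; beyond the scatter), which remains the only change shown to matter. Nothing available bears on why the two halogens read alike.

Going by these compounds, whether a methoxy group, a trifluoromethyl group or a carboxylic acid at this place would read like compound 1 stays open. So does whether the halogen swap would read the same on compound 3.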